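This account rests on a few compounds, and the source may have more. Where it says the series, first, only, none or still open, it means among the compounds named here.

Compound 1, `O=C(Nc1ccccc1)Nc1nnc(Sc2ncnc3scc(-c4ccncc4)c23)s1`, gives 19400 nM in a functional assay on HepG2 cells (Homo sapiens) for antiproliferative activity, read by MTT assay, with a stated time of 48 h; a lower number here means a stronger inhibitor, a higher number a weaker inhibitor.
Compound 2, `O=C(Nc1cccc(Cl)c1)Nc1nnc(Sc2ncnc3scc(-c4ccncc4)c23)s1`, gives 22900 nM in this assay.
Compound 3, `O=C(Nc1cccc(C(F)(F)F)c1)Nc1nnc(Sc2ncnc3scc(-c4ccncc4)c23)s1`, gives 15300 nM in this assay.

Among these three numbers compound 1 stands second highest; its nearest neighbour is compound 2 with a 1.2-fold higher number from compound 1 to compound 2 (0.07 log units; within the scatter), and the furthest is compound 3 with a 1.3-fold lower number from compound 1 to compound 3 (0.10 log units; within the scatter). The remaining step, a 1.5-fold lower number from compound 2 to compound 3 (0.18 log units; within the scatter), also stays within the scatter, so the three substituents on that ring leave the numbers where they are.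

Compound 4, `COc1ccc(NC(=O)Nc2nnc(Sc3ncnc4scc(-c5ccncc5)c34)s2)cc1`, differs from compound 1 by methoxy in place of hydrogen on an aromatic carbon. Among the measured compounds shown here, no measured step puts a methoxy on this ring, so the closest guides are the steps from compound 1 to compound 2 and from compound 1 to compound 3, where a chloro or a trifluoromethyl on an aromatic carbon of the same six-membered aromatic ring of carbon only moved nothing beyond the scatter. Compound 4 is therefore expected to show no step beyond the scatter in this assay, with a 1.0-fold lower number from compound 1 to compound 4 (0.01 log units; within the scatter) as the expected step. The estimate for compound 4 is 19000 nM, within 9000 nM to 40000 nM.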

Compound 4, half-maximal inhibitory concentration: 14600 nM
Beside the measured number, compound 4's estimate is 1.3-fold (0.11 log units) above it; measured number inside the range.
By their numbers in this assay, from the lowest: compounds 4, 3, 1 and 2 (each within the scatter of the next).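

Methoxy on an aromatic carbon para to a large group adds an oxygen-bearing substituent to the chloro and trifluoromethyl already tried on this ring, and in this assay it gives a 1.3-fold lower number from compound 1 to compound 4 (0.12 log units; within the scatter) without leaving the band of the earlier values. Set against the substituted rings of the earlier compounds, 4-methoxyphenyl gives a 1.0-fold lower number from compound 3 to compound 4 (0.02 log units; within the scatter) and a 1.6-fold lower number from compound 2 to compound 4 (0.20 log units; within the scatter) with no separation from either. All four compounds therefore remain within the scatter of one another, so this position has not yet shown a substituent that shifts the number.

No other data bear on this result.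

Still open, on these data alone, is whether an amine or a carboxylic acid on this ring would shift the number beyond the scatter. Also open, as far as these compounds go, is whether any change in the shared core would do so.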